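This account rests on a few compounds, and the source may have more. Where it says the series, first, only, none or still open, it means among the compounds named here.

Values in a functional assay on HepG2 cells (Homo sapiens) for cytotoxicity, read by MTT assay, with a stated time of 72 h; a higher number here means a weaker inhibitor, a lower number a stronger inhibitor:

- Compound 1 `Cn1cccc1-c1nc2cc(NC(=O)CCCl)ccc2[nH]1`: > 50000 nM (a limit)
- Compound 2 `Cc1ccc(-c2nc3cc(NC(=O)CN4CCCCC4)ccc3[nH]2)cc1`: > 50000 nM (a limit)
- Compound 3 `O=C(CCCl)Nc1ccc2[nH]c(-c3ccc(Br)cc3)nc2c1`: 11300 nM

Compound 1 gives no number in this assay, only a limit of the assay, > 50000 nM. Compound 2, with a six-membered non-aromatic ring on its chain, also shows only a limit, > 50000 nM.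

Compound 4 `CCN1CCN(CCC(=O)Nc2ccc3[nH]c(-c4cccn4C)nc3c2)CC1` differs from compound 1 in one place: 4-ethylpiperazin-1-yl in place of chloro on a saturated chain carbon, two bonds along the chain from a carbonyl carbon.

For the measured compounds named here, the only measured step is an at least 4.4-fold lower number from compound 1 to compound 3 (0.64 log units; beyond the scatter). It swaps the group on an aromatic carbon and leaves the chain untouched, so it bears on this change only indirectly. Compound 4 keeps the aromatic group of compound 1, and the nearest guide is the limit of > 50000 nM in this assay, at which 2 of the 3 values shown sit. No clear direction can therefore be expected in this assay. The expected result is a number no higher from compound 1 to compound 4 (the limit leaves the size open), with a reading at the limit quite likely. Compound 4 is estimated at 50000 nM, with an expected range of 15000 nM to 100000 nM.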

Compound 4, half-maximal inhibitory concentration: > 50000 nM
Compound 4: a limit, no number (the forecaster's own chance of this, stated with the estimate: 65%); the middle value lies on the limit itself.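

Compound 1 and compound 4 each give only a limit in this assay, not a number, so no step between them can be read: the limit of > 50000 nM in this assay, at which 3 of the 4 values shown sit.

The compounds shown leave open whether 4-ethylpiperazin-1-yl in place of chloro changes the reading at all.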